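Working notes on a small cytotoxicity series

This account rests on a few compounds, and the source may have more. Where it says the series, first, only, none or still open, it means among the compounds named here.

Measured so far:
compound 1 `COc1cc(-c2cc(/C=C/C(=O)c3ccc(N)cc3)[nH]n2)cc(OC)c1OC` — 91%
compound 2 `COc1ccc(-c2cc(/C=C/C(=O)c3ccc(OC)c(OC)c3)[nH]n2)cc1` — 93%

In a functional assay on RXF 393 cells (Homo sapiens) for cytotoxicity, read by sulforhodamine B assay, with a stated time of 48 h, tested at 0.1 uM (a higher number here means a weaker effect of the compound at the concentration tested, a lower number a stronger effect), compound 1 gives 91%, the lowest of the two numbers, while compound 2 gives 93%; the two values lie within the scatter of each other, so neither is set apart. Both leave most cells intact at the concentration tested.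

Compound 3 `COc1cc(-c2cc(/C=C/C(=O)c3ccc(Cl)c(Cl)c3)[nH]n2)cc(OC)c1OC` differs from compound 1 in one place: 3,4-dichlorophenyl in place of 4-aminophenyl on a carbonyl carbon. Going by the values given here, no step between measured compounds is available to size this change. The expected step of a number 3 percentage points lower from compound 1 to compound 3 (within the scatter) is none beyond the scatter, with the change unlikely to move a value that already sits near no effect. Compound 3 is estimated at 88%, within 72% to 100%.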

Compound 3, a percentage reported as activity, at one concentration (the size of the read-out at that concentration, not a potency): 96%
Compound 3: middle estimate off by 8 percentage points, on the low side; low and high end bracket the measured number.
By their numbers in this assay, from the lowest: compounds 1, 2 and 3 (each within the scatter of the next).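

In this assay, 3,4-dichlorophenyl in place of 4-aminophenyl on the carbonyl carbon gives a number 5 percentage points higher from compound 1 to compound 3 (within the scatter). At this concentration, the change therefore sets neither compound apart, even though the hydrogen-bond donor and acceptor counted on 4-aminophenyl are absent from 3,4-dichlorophenyl. No evidence on hand bears on this result.

Still open, from the compounds shown here alone, is whether a carboxylic acid or a morpholine on the same carbonyl carbon would give a reading beyond the scatter. Also open, going by these compounds, is whether compound 1 and compound 3 would separate at another concentration.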